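This account rests on a few compounds, and the source may have more. Where it says the series, first, only, none or still open, it means among the compounds named here.

Working notes on the series.

Of the compounds shown here, three sharing the same core have been measured in a functional assay on EA.hy 926 cells (Homo sapiens), read by fluorescence, tested at 10 uM; a lower number here means a weaker effect, a higher number a stronger effect of the compound at the concentration tested. Compound 1 `COc1cc(/C=C/C(=O)/C=C(/C=C/c2ccc(OC(C)=O)c(OC)c2)NC2CCCCC2)ccc1OC(C)=O` gives 113% in this assay. Compound 3 `COc1cc(/C=C/C(=O)CC(=O)/C=C/c2ccc(OC(C)=O)c(OC)c2)ccc1OC(C)=O` gives 189% in this assay. Compound 2 `CCCNC(=C\C(=O)/C=C/c1ccc(O)c(OC)c1)/C=C/c1ccc(O)c(OC)c1` gives 141% in this assay and stands second highest of the three; its nearest neighbour is compound 1, whose number is lower by a margin beyond the scatter, while compound 3 is furthest, with a number higher by a margin beyond the scatter. Going by the values given here, no pair among the measured compounds differs in a single place, so no single-point step has been characterised; the three values show only that the series spans a wide range in this assay.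

Compound 4 `COc1cc(/C=C/C(=O)/C=C(/C=C/c2ccc(O)c(OC)c2)NCC(C)C)ccc1O` has not yet been measured. It differs from compound 2 in one place: methyl in place of hydrogen on a saturated chain carbon bound to two saturated chain carbons. Cut one bond further out, the change reads propylamino to isobutylamino. Among the compounds with values here, this is a small addition of one carbon on a saturated chain, and nothing among the measured compounds speaks for a large shift in this assay from such a change, so the expected step from compound 2 to compound 4 is a number 1 percentage points lower from compound 2 to compound 4 (within the scatter), that is, none beyond the scatter. Compound 4 is therefore estimated at 140% in this assay, with a range from 115% to 165%.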

Compound 4, a percentage reported as activity, at one concentration (the size of the read-out at that concentration, not a potency): 100%
Estimate against measurement, compound 4: 40 percentage points above; measured number below the stated range.
By their numbers in this assay, from the lowest: compound 4; then compound 1; then compound 2; then compound 3.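

In this assay the series now has its first single-place step, and it is large: methyl in place of hydrogen on a saturated chain carbon bound to two saturated chain carbons, read one bond further out as propylamino to isobutylamino, gives a number 41 percentage points lower from compound 2 to compound 4 (beyond the scatter) in this series. The chain on the amino nitrogen is therefore not a silent position in this read-out, since the addition of a single carbon there moves the number beyond the scatter. Nothing at hand bears on the origin of this step.

On these data alone, whether the drop follows the branch itself or simply the added carbon remains open, and a straight butylamino chain, a cyclopropylmethylamino group or an amino chain ending in a carboxylic acid would be needed to separate these readings. Going by these compounds alone, it is also open whether the same change holds when the free hydroxyl groups carry acetyl groups, as compound 1 differs from both compound 2 and compound 4 in more than one place and gives no step to read.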